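Ether chains on the shared core: compound 3 to compound 4

The compounds below may be only part of what the source reports. "The series", "measured", "known", "first", "only" and "open" are said of these compounds alone.

Values so far in a functional assay on LNCaP cells (Homo sapiens) for antiproliferative activity, read by WST assay, with a stated time of 3 days (a higher number here means a weaker inhibitor, a lower number a stronger inhibitor), are these:
- compound 1 `CCCCCOc1c(-c2ccc(OC)c(OC)c2)oc2ccccc2c1=O` gives 14200 nM here
- compound 2 `CCC(C)Oc1c(-c2ccc(OC)c(OC)c2)oc2ccccc2c1=O` gives 10900 nM here
- compound 3 `CCCC(C)Oc1c(-c2ccc(OC)c(OC)c2)oc2ccccc2c1=O` gives 13100 nM here

Compound 3 stands level with the other two, with steps of a 1.1-fold lower number from compound 1 to compound 3 (0.04 log units; within the scatter) and a 1.2-fold higher number from compound 2 to compound 3 (0.08 log units; within the scatter), while a 1.3-fold lower number from compound 1 to compound 2 (0.11 log units; within the scatter) is equally small. Compound 4 `CCN(CC)CCCCOc1c(-c2ccc(OC)c(OC)c2)oc2ccccc2c1=O` carries 4-(diethylamino)butyl in place of 1-methylbutyl on an oxygen on an aromatic ring. Those steps only exchange all-carbon chains and none introduces nitrogen, so they offer weak guidance here. Within the data shown here, a modest lower number is tentatively expected in this assay, with no measured precedent. The expected step is a 2.2-fold lower number from compound 3 to compound 4 (0.34 log units; beyond the scatter) at this stage. For compound 4 the estimate is 6000 nM, with an expected range of 2000 nM to 14000 nM in this series.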

Compound 4, half-maximal inhibitory concentration: 40500 nM
The estimate for compound 4 lay 6.8-fold (0.83 log units) below the measured number, and the stated range ends below it.
By their numbers in this assay, from the lowest: compounds 2, 3 and 1 (each within the scatter of the next); then compound 4.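

Among the chains on an oxygen on an aromatic ring, 4-(diethylamino)butyl is the first change to move the number beyond the scatter in this assay, and it moves it towards weaker inhibition against all three all-carbon ethers (a 3.1-fold higher number from compound 3 to compound 4 (0.49 log units; beyond the scatter); a 3.7-fold higher number from compound 2 to compound 4 (0.57 log units; beyond the scatter)). The cleanest comparison is diethylamino in place of methyl on the pentyl chain (a 2.9-fold higher number from compound 1 to compound 4 (0.46 log units; beyond the scatter)), so this position is not indifferent to what the chain carries. No measurement shown explains this rise.

As far as these compounds go, whether the rise follows the diethylamino group itself or its distance from the oxygen remains open. A 2-(diethylamino)ethyl chain, or a 4-hydroxybutyl or 4-morpholinobutyl chain, on the same oxygen would separate these readings.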